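This account rests on a few compounds, and the source may have more. Where it says the series, first, only, none or still open, it means among the compounds named here.

In a functional assay on CHO cells for agonist activity at adenosine receptor A1 (Homo sapiens), read by fluorescence and ERK phosphorylation, with stated times of 30 min and 1.5 h, tested at 3 uM (a higher number here means a stronger effect of the compound at the concentration tested, a lower number a weaker effect), compound 1 `Nc1scc(-c2cccc(F)c2)c1C(=O)c1ccccc1` gives 51%. Compound 2 `Nc1scc(-c2cccc([N+](=O)[O-])c2)c1C(=O)c1ccccc1` gives 47% in the same assay, and among the two numbers measured it stands nearest compound 1, separated by the step of a number 4 percentage points lower from compound 1 to compound 2 (within the scatter), which lies within the scatter. Compound 3 `COc1cccc(-c2csc(N)c2C(=O)c2ccccc2)c1` differs from compound 2 by methoxy in place of nitro on an aromatic carbon. Going by the values given here, no measured step exchanges nitro for methoxy; the single step at hand, a number 4 percentage points lower from compound 1 to compound 2 (within the scatter), shows that swapping one group for another on this aromatic carbon left the read-out within the scatter. The step expected from compound 2 to compound 3 is therefore a number 1 percentage points higher from compound 2 to compound 3 (within the scatter), nothing beyond the scatter. Compound 3 is thus estimated at 48%, with a range from 30% to 66%.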

Compound 3, a percentage reported as activity, at one concentration (the size of the read-out at that concentration, not a potency): 41%
Compound 3: middle estimate off by 7 percentage points, on the high side, and the stated range covers the measured number.
By their numbers in this assay, from the lowest: compounds 3, 2 and 1 (each within the scatter of the next).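

In this assay methoxy now joins fluoro and nitro on this aromatic carbon, with a number 6 percentage points lower from compound 2 to compound 3 (within the scatter) and a number 10 percentage points lower from compound 1 to compound 3 (within the scatter) as its two steps. Across these three groups, all steps stay within the scatter, so the change to methoxy separates none of them and they cannot be ranked at this position. Nothing measured here offers an explanation for these numbers. On these data alone, whether an amine, a carboxylic acid or a longer chain on this carbon would also stay within the scatter remains open.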